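A few compounds are considered here, and "the series" means these few. Any claim that something is new, unique, unknown or untested is made for them only; others in the source may bear on it.

Series notes, cytotoxicity branch. Within the data shown here, the two measured members share one core: compound 1 `Cc1cc(C)c(Oc2cc(Nc3ccc(C#N)cc3)ncc2C(=O)NCc2cn(CC(N)=O)nn2)c(C)c1` and compound 2 `COC(=O)Cn1cc(CNC(=O)c2cnc(Nc3ccc(C#N)cc3)cc2Oc2c(C)cc(C)cc2C)nn1`. In an ADME assay on MT4 cells (Homo sapiens) for cytotoxicity, read by MTT assay, with a stated time of 5 days (a higher number here means that more compound is tolerated, a lower number that less compound is tolerated), compound 1 gives 24000 nM, and compound 2 gives 13800 nM. Among the measured compounds shown here, compound 1 thus holds the highest of the two numbers so far, but its only neighbour sits close: the step of a 1.7-fold lower number from compound 1 to compound 2 (0.24 log units; within the scatter) does not leave the scatter, so the two compounds are not distinguished by this assay.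

The next member, compound 3 `Cc1cc(C)c(Oc2cc(Nc3ccc(C#N)cc3)ncc2C(=O)NCc2cn(Cc3cccc([N+](=O)[O-])c3)nn2)c(C)c1`, departs from compound 1 by a single change: 3-nitrophenyl in place of carbamoyl on a saturated chain carbon bound to an aromatic nitrogen. For the measured compounds named here, the only measured step, the one from compound 1 to compound 2, also alters the carbamoylmethyl group, but exchanges a small part of it for another small part, and it came out within the scatter. Going by the values given here, the change to compound 3 is of a different kind and size, a small acyclic group leaving and an aromatic ring entering, so no measured step directly bears on it. The expected step, a 2.4-fold lower number from compound 1 to compound 3 (0.38 log units; beyond the scatter), is toward a lower number and with wide uncertainty. Compound 3 is therefore estimated at 10000 nM, with a range from 3000 nM to 30000 nM.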

Compound 3, half-maximal cytotoxic concentration: >= 156000 nM
Compound 3: no number, only a limit; the forecaster's own chance of this, stated with the estimate: 15%; middle value at least 15-fold (1.19 log units) away from the limit.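

In this assay compound 3 gives no number, only a limit of the assay, >= 156000 nM, and that limit is the top of what is shown here: the limit of >= 156000 nM in this assay, at which 1 of the 3 values shown sits.

Even read from that limit, this position on a saturated chain carbon bound to an aromatic nitrogen responds to the change, with an at least 6.5-fold higher number from compound 1 to compound 3 (0.81 log units; beyond the scatter) and an at least 11-fold higher number from compound 2 to compound 3 (1.05 log units; beyond the scatter), whereas the exchange of one small group for another gave only a 1.7-fold lower number from compound 1 to compound 2 (0.24 log units; within the scatter). Carbamoylmethyl to 3-nitrobenzyl is thus the first change in the series that this assay separates, and it goes toward more compound tolerated, with the full size of the step unknown since one end of it is a limit.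

The compounds shown do not tell whether the aromatic ring alone carries this step or whether the nitro group on it takes part, a question that an unsubstituted benzyl group, or a benzyl group bearing an amine or a carboxylic acid instead of the nitro group, would address. Also open, as far as these compounds go, is how a longer chain at this place, between the aromatic nitrogen and the phenyl ring, would read in this assay.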